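A few compounds are considered here, and "the series" means these few. Any claim that something is new, unique, unknown or untested is made for them only; others in the source may bear on it.

Compound 1 `CCC(C(=O)N1CCN(c2cccc(Cl)c2)CC1)N1C(=O)CCC1=O`: 100% in a functional assay on the whole organism (strain Swiss) with Mus musculus as the target, in the maximal electroshock model, with a stated time of 1 h, at a dose of 300 mg/kg by the intraperitoneal route; on this read-out higher numbers stand for a stronger effect at the one dose given and lower numbers for a weaker effect
Compound 2 `CC(C(=O)N1CCN(c2cccc(Cl)c2)CC1)N1C(=O)CCC1=O`: 75% in this assay
Compound 3 `CCC(C(=O)N1CCN(c2ccccc2)CC1)N1C(=O)CCC1=O`: 75% in this assay

Compound 2 stands level with compound 3 at the digits shown, and together they are the lowest of the three numbers; from compound 1 the step of a number 25 percentage points lower from compound 1 to compound 2 (beyond the scatter) separates them. Compound 4 `CC(C(=O)N1CCN(c2ccccc2F)CC1)N1C(=O)CCC1=O` has not been measured yet. It differs from compound 2 by 2-fluorophenyl in place of 3-chlorophenyl on an amine nitrogen in a ring. For the measured compounds named here, no measured pair swaps one halogen for another on that ring, but one step bears on it: hydrogen in place of chloro on an aromatic carbon gave a number 25 percentage points lower from compound 1 to compound 3 (beyond the scatter). A fluoro entering the ring may recover part of that loss, so the expected step of a number 15 percentage points lower from compound 2 to compound 4 (beyond the scatter) is a small decrease, perhaps within the scatter. Compound 4 is therefore estimated at 60%, ranging from 25% to 100%.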

Compound 4, a percentage reported as activity, at one dose (the size of the read-out at that dose, not a potency): 50%
The estimate for compound 4 lay 10 percentage points above the measured number; measured number inside the range.
By their numbers in this assay, from the lowest: compound 4; then compounds 2 and 3 (each within the scatter of the next); then compound 1.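

In this assay, swapping 3-chlorophenyl for 2-fluorophenyl on the amine nitrogen gives a number 25 percentage points lower from compound 2 to compound 4 (beyond the scatter), so a halogen on this aromatic ring does not by itself hold the number up. The swap changes both the halogen and where it sits, and this single step cannot separate the two. Nothing measured here explains the drop.

Still open, from the compounds shown here alone, is how a methoxy group or a bromo on that aromatic ring would compare, and whether either would match the chloro of compound 2.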